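Swapping the acyl chain for a phenylcyclopentyl group

A few compounds are considered here, and "the series" means these few. Any claim that something is new, unique, unknown or untested is made for them only; others in the source may bear on it.

Measured so far:
Compound 1 `O=C(CCCc1cccs1)N[C@@H]1[C@@H](O)[C@H](n2cnc3c(NC4CCCC4)ncnc32)O[C@@H]1CO` gives 46 nM in an assay on isolated protein for binding affinity to adenosine receptor A1 (Rattus norvegicus), in the presence of a further agent that is not named here; on this read-out higher numbers stand for weaker inhibition and lower numbers for stronger inhibition.
Compound 2 `C[C@H]1O[C@@H](n2cnc3c(NC4CCCC4)ncnc32)[C@H](O)[C@H]1NC(=O)CCCc1cccs1` gives 38 nM.
Compound 3 `C[C@H]1O[C@@H](n2cnc3c(NC4CCCC4)ncnc32)[C@H](O)[C@H]1NC(=O)C1CCCC[C@H]1C(=O)c1cccs1` gives 70 nM.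

Compound 2 has the lowest number of the three, but none of the gaps around it counts as real: the step of a 1.2-fold lower number from compound 1 to compound 2 (0.08 log units; within the scatter) is within the scatter, and the gap between compound 2 and compound 3 is within the scatter as well, so the three compounds cannot be ranked.

Compound 4 `C[C@H]1O[C@@H](n2cnc3c(NC4CCCC4)ncnc32)[C@H](O)[C@H]1NC(=O)C1(c2ccccc2)CCCC1` differs from compound 2 in one place: 1-phenylcyclopentyl in place of 3-(thiophen-2-yl)propyl on a carbonyl carbon. For the measured compounds named here, no measured step changes this acyl group, so nothing measured bears directly on it. Going by the values given here, the one measured step, from compound 1 to compound 2, touches a different part of the molecule and is small. Compound 3 carries a different bulky ring-bearing acyl group, and its value against that of compound 2 shows only a gap within the scatter. A modest weakening is therefore expected, and the estimated step of a 2.1-fold higher number from compound 2 to compound 4 (0.32 log units; beyond the scatter) is likely to stay near the edge of the scatter. Compound 4 is estimated at 80 nM, between 30 nM and 250 nM.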

Compound 4, inhibition constant: 114 nM
The estimate for compound 4 lay 1.4-fold (0.15 log units) below the measured number; low and high end bracket the measured number.
By their numbers in this assay, from the lowest: compounds 2, 1, 3 and 4 (each within the scatter of the next, the first and the last beyond it).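

In this assay, the group on the carbonyl carbon now has its first measured step: a 3.0-fold higher number from compound 2 to compound 4 (0.48 log units; beyond the scatter). This step goes beyond the scatter, so this place does respond to the group it carries, and replacing 3-(thiophen-2-yl)propyl with 1-phenylcyclopentyl costs a modest amount of binding strength. No measurement shown explains this loss.

The compounds shown do not separate the effects of removing the thiophene ring, adding the phenyl ring and adding the cyclopentyl ring, since all three changes occur together in this one step. A 3-phenylpropyl chain on the same carbonyl carbon would test the aromatic ring alone, leaving the chain in place, while a cyclopentyl group without the phenyl ring would test the saturated ring alone.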